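The source may report more compounds than this note shows. Statements on the series, on what has been measured and on what is new or still open speak of the compounds shown alone.

Measured compounds:
compound 1 `CCOC(=O)c1cnn(-c2nc(-c3ccccc3Cl)c(C#N)c(=O)n2C)c1N` — 102 ug/mL
compound 2 `CN(C)c1ccc(-c2nc(NN)n(C)c(=O)c2C#N)cc1` — 63 ug/mL
compound 3 `COc1cccc(-c2nc(SC)n(C)c(=O)c2C#N)c1OC` — 48 ug/mL

In a functional assay on microsomes for inhibition, with a stated time of 1 h (on this read-out lower numbers stand for stronger inhibition and higher numbers for weaker inhibition), compound 1 gives the highest number of the three shown. Compound 2 is the nearest, and its value differs from that of compound 1 by less than the scatter, so the two cannot be told apart. Compound 3 gives a lower number than compound 1 by a margin beyond the scatter. For the measured compounds named here, no pair of measured compounds differs in one place only, so no measured step is available to lean on.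

Compound 4 `CCOC(=O)c1cnn(-c2nc(-c3ccccc3O)c(C#N)c(=O)n2C)c1N` differs from compound 1 in one place: hydroxy in place of chloro on an aromatic carbon. In this assay only a small step is expected, a 1.1-fold lower number from compound 1 to compound 4 (0.05 log units; within the scatter), with no direction clear beyond the scatter. Compound 4 is estimated at 90 ug/mL, within 40 ug/mL to 200 ug/mL.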

Compound 4, half-maximal inhibitory concentration: 57 ug/mL
Estimate against measurement, compound 4: 1.6-fold (0.20 log units) above, within the range that was stated.
By their numbers in this assay, from the lowest: compounds 3, 4, 2 and 1 (each within the scatter of the next, the first and the last beyond it).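

In this assay, for the compounds shown here, the exchange gives a 1.8-fold lower number from compound 1 to compound 4 (0.25 log units; within the scatter), the first one-place comparison, and 2-chlorophenyl and 2-hydroxyphenyl cannot be told apart at this position. Hydroxy brings a hydrogen-bond donor and acceptor that chloro lacks, yet the read-out does not separate the two compounds. No measured evidence bears on this result.

Still open, from the compounds shown here alone, is whether an amine or methoxy on this aromatic carbon would separate from chloro beyond the scatter. Also open, going by these compounds, is whether the same exchange reads alike on the cores of compound 2 and compound 3.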